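Hydroxy for methyl on the aryl ring of the series

The source may hold more compounds than are shown below. What is called first, only, known or untested is meant among the compounds shown, and "the series" means these compounds.

Measured so far in a physicochemical assay for lipophilicity, measured as octanol-water partition; on this read-out higher numbers stand for higher lipophilicity and lower numbers for lower lipophilicity:
- compound 1, `Cc1c(NCc2nnc(-c3ccc(Cl)cc3)o2)c(=O)n(-c2ccccc2)n1C`: 2.7
- compound 2, `Cc1c(NCc2nnc(-c3ccc(N)cc3)o2)c(=O)n(-c2ccccc2)n1C`: 1.13
- compound 3, `Cc1ccccc1-c1nnc(CNc2c(C)n(C)n(-c3ccccc3)c2=O)o1`: 2.38

Compound 3 stands second highest of the three numbers; its nearest neighbour is compound 1, shown by a number 0.32 log units lower from compound 1 to compound 3 (beyond the scatter), and its furthest is compound 2, shown by a number 1.25 log units higher from compound 2 to compound 3 (beyond the scatter). The largest move in the set is a number 1.57 log units lower from compound 1 to compound 2 (beyond the scatter), where a polar donor group replaced a halogen on the same aromatic carbon.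

Compound 4, `Cc1c(NCc2nnc(-c3ccccc3O)o2)c(=O)n(-c2ccccc2)n1C`, is not yet measured. It differs from compound 3 as follows: hydroxy in place of methyl on an aromatic carbon. The change that bears on it most directly is the chloro-to-amino step, since there too a group carrying a hydrogen-bond donor and acceptor entered the aryl ring, and that step was large and downward. The present change is of the same kind, so a downward step in this assay beyond the scatter is expected, though it need not reach the full size of the earlier one. The expected step is a number 0.88 log units lower from compound 3 to compound 4 (beyond the scatter). For compound 4 the estimate is 1.5, with a range from 1 to 2.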

Compound 4, partition coefficient: 1.71
Compound 4: middle estimate off by 0.21 log units, on the low side; the range from low to high includes it.
By their numbers in this assay, from the lowest: compound 2; then compound 4; then compound 3; then compound 1.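

Working notes on the aryl ring: in this assay, hydroxy in place of methyl on an aromatic carbon ortho to a large group gives a number 0.67 log units lower from compound 3 to compound 4 (beyond the scatter) and so shows that this one exchange at this place moves the read-out by a modest step. Compound 4 falls between the two para-substituted aryl compounds, with a number 0.58 log units higher from compound 2 to compound 4 (beyond the scatter) and a number 0.99 log units lower from compound 1 to compound 4 (beyond the scatter) in the same read-out. No measurement in hand accounts for the size of these steps.

Open, as far as these compounds go, is whether methoxy or a carboxylic acid at this same place gives a step of similar size. Also open, from the compounds shown here alone, is whether hydroxy for methyl gives the same step on another aromatic carbon of this ring.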